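This account rests on a few compounds, and the source may have more. Where it says the series, first, only, none or still open, it means among the compounds named here.

Of the compounds shown here, three sharing one core have been measured in a functional assay on HCT-116 cells (Homo sapiens) for antiproliferative activity, read by sulforhodamine B assay, with a stated time of 4 days; a higher number here means a weaker inhibitor of growth, a lower number a stronger inhibitor of growth. Compound 1 `COc1cc(Cl)c(-c2nc(SCC(=O)NC(C)C)nc3[nH]cc(C#N)c23)cc1O`, with a hydrogen on an oxygen on its aromatic ring, gives 238 nM. Ethyl on that oxygen gives compound 2 `CCOc1cc(-c2nc(SCC(=O)NC(C)C)nc3[nH]cc(C#N)c23)c(Cl)cc1OC`, at 65 nM, and methyl gives compound 3 `COc1cc(Cl)c(-c2nc(SCC(=O)NC(C)C)nc3[nH]cc(C#N)c23)cc1OC`, at 81 nM. The ethyl change is a 3.7-fold lower number from compound 1 to compound 2 (0.56 log units; beyond the scatter), and the methyl change is a 2.9-fold lower number from compound 1 to compound 3 (0.47 log units; beyond the scatter). The comparison of the two capped compounds is a 1.2-fold higher number from compound 2 to compound 3 (0.10 log units; within the scatter). Compound 3 therefore stands level with compound 2 and clearly under compound 1.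

Compound 4 `COc1cc(Cl)c(-c2nc(SCC(=O)N3CCC3)nc3[nH]cc(C#N)c23)cc1OC` keeps the rest of compound 3 but changes the far end of the amide: azetidin-1-yl in place of isopropylamino on a carbonyl carbon. Azetidin-1-yl takes the place of isopropylamino on the carbonyl carbon, and the amide hydrogen is gone. For the measured compounds named here, none of the measured steps touches this amide, so the data give no direct guide to its effect. They show only the size of change seen so far in this small set, with a 3.7-fold lower number from compound 1 to compound 2 (0.56 log units; beyond the scatter) as the largest. A step no larger than that is expected, most likely within the scatter and leaning towards a higher number in this assay. The expected change is a 1.4-fold higher number from compound 3 to compound 4 (0.13 log units; within the scatter). For compound 4 the estimate is 110 nM, with an expected range from 35 nM to 350 nM.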

Compound 4, concentration for 50% growth inhibition: 28 nM
For compound 4 the middle estimate is 3.9-fold (0.59 log units) above the measured one; measured number below the stated range.
By their numbers in this assay, from the lowest: compound 4; then compounds 2 and 3 (each within the scatter of the next); then compound 1.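

In this assay azetidin-1-yl in place of isopropylamino gives a 2.9-fold lower number from compound 3 to compound 4 (0.46 log units; beyond the scatter) and is the first change shown at the far end of the amide, so this end of the molecule, as well as the oxygen on the aromatic ring, can move the number. The heavy atoms stay the same in count and kind, with 3 carbon and 1 nitrogen on each side of the swap, so the difference lies in how they are arranged: the amide hydrogen is gone and the group is closed into a four-membered ring. Nothing measured here accounts for the step, and this single pair changes both features at once, so it cannot assign the lower number to either one.

A dimethylamino group would lack the amide hydrogen without forming a ring, while a cyclobutylamino group would keep that hydrogen and carry a ring, so either could separate the two features. Larger rings on the carbonyl carbon, such as pyrrolidine or piperidine, remain open, as does whether azetidin-1-yl gives a similar step with the ethyl ether of compound 2.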